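Acrylamide anilino series: aryl swap at the ring nitrogen

This account rests on a few compounds, and the source may have more. Where it says the series, first, only, none or still open, it means among the compounds named here.

Compound 2 `C=CC(=O)Nc1cccc(NC(=O)CSc2nc(Nc3ccccc3Cl)c3ccccc3n2)c1` carries a 2-chlorophenyl group on the ring nitrogen and an acrylamide-bearing anilide. In a functional assay on NCI-H1975 cells (Homo sapiens) for inhibition, read by MTT assay, with a stated time of 72 h (on this read-out higher numbers stand for weaker inhibition and lower numbers for stronger inhibition), compound 2 gives 10000 nM. Within the data shown here, compound 1 `O=C(CSc1nc(Nc2ccccc2)c2ccccc2n1)Nc1ccc(F)c(Cl)c1` is the only other measured member; in this assay compound 1 gives 9390 nM, and the two numbers sit within the scatter of each other, so neither can be set apart from the other on this read-out. Compound 3 `C=CC(=O)Nc1cccc(NC(=O)CSc2nc(Nc3cccc(F)c3)c3ccccc3n2)c1` is the next member to be tested. It differs from compound 2 in one place: 3-fluorophenyl in place of 2-chlorophenyl on a nitrogen on an aromatic ring. Among the measured compounds shown here, no measured pair isolates this kind of change, so there is no step to lean on. The expectation for compound 3 is therefore a step of no change at the digits printed from compound 2 to compound 3 (within the scatter), no larger than the scatter in either direction. Compound 3 is estimated at 10000 nM, with a range from 4000 nM to 25000 nM.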

Compound 3, half-maximal inhibitory concentration: 2030 nM
Estimate against measurement, compound 3: 4.9-fold (0.69 log units) above; measured number outside the range, below it.
By their numbers in this assay, from the lowest: compound 3; then compounds 1 and 2 (each within the scatter of the next).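

On a nitrogen on an aromatic ring, the aryl group is now shown to matter in the acrylamide series: in this assay, 3-fluorophenyl in place of 2-chlorophenyl gives a 4.9-fold lower number from compound 2 to compound 3 (0.69 log units; beyond the scatter), a modest step beyond the scatter. The earlier pair could not show this, since compound 1 and compound 2 differ in more than one place and their values lie within the scatter of each other. The two aryl groups match in heavy-atom count and in hydrogen-bond donors and acceptors, and nothing measured here explains the step.

The halogen and its ring position change together in this single step, so the compounds shown do not separate the two. A 3-chlorophenyl or 2-fluorophenyl group on the same nitrogen would separate them, and an unsubstituted phenyl group would show what either halogen contributes within the acrylamide series.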